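The source may hold more compounds than are shown below. What is called first, only, known or untested is meant among the compounds shown, and "the series" means these compounds.

Working notes on the series. In a functional assay on MIA PaCa-2 cells (Homo sapiens) for cytotoxicity, read by luminescence, with a stated time of 72 h, in the presence of a further agent that is not named here (on this read-out lower numbers stand for stronger inhibition and higher numbers for weaker inhibition), compound 1 `CN(C)C(=S)NN=Cc1nccc2ccccc12` gives 73.7 nM and compound 2 `CNc1cccc2c(C=NNC(=S)N(C)C)ncc(F)c12` gives 42.3 nM; compound 2 holds the lowest of the two numbers, and the gap to compound 1 lies within the scatter, so no order can be read from the pair. Compound 3 `CN(C)C(=S)NN=Cc1ncc(F)c2ccccc12` differs from compound 2 by hydrogen in place of methylamino on an aromatic carbon. Among the compounds with values here, no measured pair isolates this change, so no step beyond the scatter is expected from compound 2 to compound 3, in either direction. For compound 3 the estimate in this assay is 55 nM, with a range of 25 nM to 120 nM, which implies an expected step of a 1.3-fold higher number from compound 2 to compound 3 (0.11 log units; within the scatter).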

Compound 3, half-maximal inhibitory concentration: 26.6 nM
Compound 3: middle estimate off by 2.1-fold (0.32 log units), on the high side; the range from low to high includes it.
By their numbers in this assay, from the lowest: compounds 3, 2 and 1 (each within the scatter of the next, the first and the last beyond it).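

In this assay the change from methylamino to hydrogen on an aromatic carbon gives a 1.6-fold lower number from compound 2 to compound 3 (0.20 log units; within the scatter) and so leaves no readable difference between these two groups at this position. Fluoro in place of hydrogen on an aromatic carbon gives a 2.8-fold lower number from compound 1 to compound 3 (0.44 log units; beyond the scatter) as the first step in the series beyond the scatter, though a modest one. No evidence at hand bears on either step.

On these data alone, whether a larger amine such as dimethylamino or a methoxy group at the methylamino position would also stay within the scatter remains open. As far as these compounds go, the fluoro step is known only with hydrogen at that position, so its size with methylamino present is also open.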